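A few compounds are considered here, and "the series" means these few. Any claim that something is new, unique, unknown or untested is made for them only; others in the source may bear on it.

Measured so far in a functional assay on HeLa cells (Homo sapiens) for inhibition, read by CCK-8 assay, with a stated time of 72 h, tested at 2 uM; a lower number here means less inhibition of growth, a higher number more inhibition of growth at the concentration tested:
compound 1 `COc1ccc(SCc2ccc(/C=C/C(=O)Nc3ccccc3N)cc2)cc1OC` gives 10.1%
compound 2 `Nc1ccccc1NC(=O)c1ccc(CSc2nccc(C(F)(F)F)n2)cc1` gives 68.3%
compound 3 `Nc1ccccc1NC(=O)c1ccc(CSc2ccc(Br)cc2)cc1` gives 18.8%

Compound 1 stands lowest of the three numbers in this assay. Its nearest neighbour is compound 3, whose value lies within the scatter of that of compound 1; compound 2 lies well beyond the scatter, the only one of the three to do so.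

Compound 4 `Nc1ccccc1NC(=O)/C=C/c1ccc(CSc2ccc(Cl)cc2)cc1` keeps the core of compound 1 and differs in one place: 4-chlorophenyl in place of 3,4-dimethoxyphenyl on a sulfur. Compound 3 also carries a halogenated phenyl on the sulfur and sits within the scatter of compound 1, so no step beyond the scatter is expected here. The step of a number 4.9 percentage points higher from compound 1 to compound 4 (within the scatter) is expected to be small, with no clear direction. Compound 4 is expected to give 15%, with a range from 4% to 35%.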

Compound 4, percent growth inhibition at one concentration: 1.94%
For compound 4 the middle estimate is 13.1 percentage points above the measured one; the measured number lies below the stated range.
By their numbers in this assay, from the lowest: compounds 4, 1 and 3 (each within the scatter of the next, the first and the last beyond it); then compound 2.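

In this assay, going by these compounds alone, the change to 4-chlorophenyl in place of 3,4-dimethoxyphenyl on a sulfur gives a number 8.2 percentage points lower from compound 1 to compound 4 (within the scatter) and is the first single-place comparison. On the core of compound 1, this position therefore tolerates the loss of the hydrogen-bond acceptors of 3,4-dimethoxyphenyl without a step beyond the scatter. No available evidence bears on this result. On these data alone, whether an amine or a carboxylic acid on the phenyl ring at this sulfur would move the number beyond the scatter remains open.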